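Phenyl in place of methyl on the core of compound 2

The source may report more compounds than this note shows. Statements on the series, on what has been measured and on what is new or still open speak of the compounds shown alone.

Compound 2 `C/C(=N\Nc1nc(-c2ccc(Br)cc2)cs1)c1sc(C)nc1C` is the parent here. In a toxicity assay on MCF7 cells (Homo sapiens) for cytotoxicity, read by MTT assay (a higher number here means a weaker inhibitor of growth, a lower number a stronger inhibitor of growth), compound 2 gives > 100 ug/mL, which is a limit of the assay and not a number. Compound 1 `C/C(=N\Nc1nc(-c2ccc(Cl)cc2)cs1)c1sc(C)nc1C` in this assay gives > 100 ug/mL, again a limit. Compound 3 `C/C(=N\Nc1nc(-c2ccc(C)cc2)cs1)c1sc(C)nc1C` in this assay gives > 100 ug/mL, also a limit. All three values sit at the same limit (the limit of > 100 ug/mL in this assay, at which 3 of the 3 values shown sit), so compound 2 stands level with its two neighbours as far as the numbers can tell. The steps a step that the two limits leave unreadable from compound 1 to compound 2, a step that the two limits leave unreadable from compound 1 to compound 3 and a step that the two limits leave unreadable from compound 2 to compound 3 are therefore of unreadable size, and they alter only the substituent on the pendant aromatic ring, not the position changed here.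

Compound 4 `C/C(=N\Nc1nc(-c2ccc(Br)cc2)cs1)c1sc(-c2ccccc2)nc1C` differs from compound 2 by phenyl in place of methyl on an aromatic carbon. Among the compounds with values here, no measured step touches this position, so nothing reads on the size or direction of this change. The expectation for compound 4 in this assay is 90 ug/mL (range 40 ug/mL to 200 ug/mL), a step of an at least 1.1-fold lower number from compound 2 to compound 4 (0.04 log units; that floor lies within the scatter) that is an estimate resting on the shared limit of compound 2 at > 100 ug/mL and carrying a strong chance of again returning only a limit.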

Compound 4, concentration for 50% growth inhibition: 26.3 ug/mL
Compound 4: middle estimate off by 3.4-fold (0.53 log units), on the high side, and the stated range ends above it.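

Within the data shown here, the position on the core, next to the ring nitrogen and next to the ring sulfur, is the first place where a change can be read: in this assay, phenyl in place of methyl gives an at least 3.8-fold lower number from compound 2 to compound 4 (0.58 log units; beyond the scatter). For compound 2 the value > 100 ug/mL is a limit of the assay and not a number. The steps among compounds 1, 2 and 3 on the pendant aromatic ring cannot be read, and compound 4 alone stands off the shared limit: the limit of > 100 ug/mL in this assay, at which 3 of the 4 values shown sit.

Going by these compounds, whether the lower number belongs to phenyl as such stays open: an amine, a cyclohexyl group or a longer chain at this position would bear on that. Equally open, on these data alone, is whether chloro or methyl on the pendant aromatic ring reads differently with phenyl on the core.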